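From 4-ethylphenyl to 3,5-dimethylphenyl on a sulfur

This account rests on a few compounds, and the source may have more. Where it says the series, first, only, none or still open, it means among the compounds named here.

Compound 1 `COc1ccc(SCc2ccc(C(=O)Nc3ccccc3N)cc2)cc1`: 4040 nM
Compound 2 `CCc1ccc(SCc2ccc(C(=O)Nc3ccccc3N)cc2)cc1`: 3660 nM
Compound 3 `Nc1ccccc1NC(=O)c1ccc(CSc2nccc(C(F)(F)F)n2)cc1`: 1850 nM

These three numbers come from an ADME assay on NIH3T3 cells (Mus musculus) for cytotoxicity, read by CCK-8 assay, with a stated time of 72 h; on this read-out lower numbers stand for stronger inhibition and higher numbers for weaker inhibition. In this assay, compound 2 gives 3660 nM, a number within the usual scatter of those for both compound 1 and compound 3. The three compounds therefore offer little separation from which to read a trend.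

The next compound to be tested is compound 4 `Cc1cc(C)cc(SCc2ccc(C(=O)Nc3ccccc3N)cc2)c1`. It keeps the shared core and the sulfur and carries 3,5-dimethylphenyl in place of 4-ethylphenyl on that sulfur: 3,5-dimethylphenyl in place of 4-ethylphenyl on a sulfur. Going by the values given here, no measured step makes this exact change. The closest evidence is a 1.1-fold lower number from compound 1 to compound 2 (0.04 log units; within the scatter), where ethyl takes the place of methoxy on an aromatic carbon. Among the compounds with values here, that step stayed within the scatter, and it is the only single-place step available. It gives no ground for expecting a shift in either direction, so no change beyond the scatter is expected in this assay.

The expected change is a 1.0-fold lower number from compound 2 to compound 4 (0.02 log units; within the scatter). Compound 4 is estimated at 3500 nM, with an expected range from 1700 nM to 7000 nM.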

Compound 4, half-maximal inhibitory concentration: 3340 nM
For compound 4 the middle estimate is 1.0-fold (0.02 log units) above the measured one, and the stated range covers the measured number.
By their numbers in this assay, from the lowest: compounds 3, 4, 2 and 1 (each within the scatter of the next, the first and the last beyond it).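

In this assay, the step of a 1.1-fold lower number from compound 2 to compound 4 (0.04 log units; within the scatter) shows that exchanging 4-ethylphenyl for 3,5-dimethylphenyl on the sulfur, with the same atoms joined differently, leaves the number within the scatter. The step of a 1.2-fold lower number from compound 1 to compound 4 (0.08 log units; within the scatter), which puts 3,5-dimethylphenyl in place of 4-methoxyphenyl, also stays within the scatter, so compounds 1, 2 and 4 cannot be told apart here, even though their aromatic groups on this sulfur differ in both substituent and arrangement. Nothing available offers a reason for this flat result.

These three compounds cover only neutral carbon-ring groups bearing methoxy, ethyl or methyl, and they leave open how far this tolerance extends, for instance to a phenyl group carrying an amine or a carboxylic acid, or to a longer chain in place of ethyl. They also leave open what lies behind the printed values of compound 3 at 1850 nM and compound 1 at 4040 nM, which stand beyond the scatter of each other, since no series of single changes here connects the trifluoromethyl-bearing group of compound 3 to the phenyl groups.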